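The compounds below may be only part of what the source reports. "The series", "measured", "known", "first", "only" and "open" are said of these compounds alone.

Measured compounds in a functional assay on MIA PaCa-2 cells (Homo sapiens) for inhibition, read by MTT assay, with a stated time of 72 h; on this read-out higher numbers stand for weaker inhibition of growth and lower numbers for stronger inhibition of growth:
compound 1 `O=S(=O)(NCCCCNCc1ccc(Br)cc1)c1cc(C(F)(F)F)cc(C(F)(F)F)c1` gives 2100 nM
compound 2 `O=S(=O)(NCCCCCCNCc1ccc(Br)cc1)c1ccccc1Cl` gives 13700 nM

Of the two, compound 2 has the higher number in this assay, and the gap to compound 1 lies beyond the scatter. Compound 3 `COc1ccc(S(=O)(=O)NCCCCCCNCc2ccc(Br)cc2)cc1` has not been measured. It differs from compound 2 in one place: 4-methoxyphenyl in place of 2-chlorophenyl on a sulfonyl sulfur. Nothing measured bears on this exchange, so the step from compound 2 to compound 3 cannot be anchored; a step of modest size in either direction, or none beyond the scatter, is expected, as a 1.1-fold higher number from compound 2 to compound 3 (0.04 log units; within the scatter). Compound 3 is therefore estimated at 15000 nM, within a range from 6000 nM to 40000 nM.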

Compound 3, concentration for 50% growth inhibition: 13000 nM
Compound 3: middle estimate off by 1.2-fold (0.06 log units), on the high side; the measured number falls inside the stated range.
By their numbers in this assay, from the lowest: compound 1; then compounds 3 and 2 (each within the scatter of the next).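

In this assay, placing 4-methoxyphenyl in place of 2-chlorophenyl on a sulfonyl sulfur gives a 1.1-fold lower number from compound 2 to compound 3 (0.02 log units; within the scatter). Within the data shown here, this is the first step that can be read at this position, and it shows that the exchange, which removes a chlorine and brings in an oxygen with one hydrogen-bond acceptor, leaves the number within the scatter. No available evidence bears on this result.

The compounds shown leave open whether an amine or a carboxylic acid on the aromatic ring would shift the number beyond the scatter. They also leave open what a longer chain would do.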